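Trimming the Ester of Compound 3: Expected Cytotoxicity

The source may report more compounds than this note shows. Statements on the series, on what has been measured and on what is new or still open speak of the compounds shown alone.

Within the data shown here, compound 3 `O=C(CN1C(=O)c2ccccc2C1=O)OCCc1c(-c2ccccc2Cl)c2cc(Cl)ccc2[nH]c1=O` gives 960000 nM in an ADME assay on HepG2 2.2.15 cells (Homo sapiens) for cytotoxicity (a lower number here means that less compound is tolerated, a higher number that more compound is tolerated), the highest of the three numbers known. Compound 1 `CC(=O)OCCc1c(-c2ccccc2Cl)c2cc(Cl)ccc2[nH]c1=O` gives 27000 nM, and compound 2 `CCCCCCCC(=O)OCCc1c(-c2ccccc2Cl)c2cc(Cl)ccc2[nH]c1=O` gives 78000 nM. The steps of a 36-fold higher number from compound 1 to compound 3 (1.55 log units; beyond the scatter) and a 12-fold higher number from compound 2 to compound 3 (1.09 log units; beyond the scatter) show that the larger group on the saturated chain carbon bound to a carbonyl carbon went with a much higher number, whereas a 2.9-fold higher number from compound 1 to compound 2 (0.46 log units; beyond the scatter) was only modest. Compound 4 `C/C=C/C(=O)OCCc1c(-c2ccccc2Cl)c2cc(Cl)ccc2[nH]c1=O` carries a group of 3 heavy atoms (3 carbon; no ring) in place of a group of 12 heavy atoms (9 carbon, 1 nitrogen, 2 oxygen; one five-membered non-aromatic ring with 1 hetero atom, one six-membered aromatic ring of carbon only), on a carbonyl carbon. Because this change takes away the group whose arrival produced a 36-fold higher number from compound 1 to compound 3 (1.55 log units; beyond the scatter), a large fall is expected. Compound 4 is expected to show a 27-fold lower number from compound 3 to compound 4 (1.44 log units; beyond the scatter), landing near compound 1 and compound 2. Compound 4 is therefore estimated at 35000 nM, with a range from 15000 nM to 90000 nM.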

Compound 4, half-maximal cytotoxic concentration: 30000 nM
The estimate for compound 4 lay 1.2-fold (0.07 log units) above the measured number; the measured number falls inside the stated range.
By their numbers in this assay, from the lowest: compounds 1 and 4 (each within the scatter of the next); then compound 2; then compound 3.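

Swapping the group with the two rings for prop-1-en-1-yl on this carbonyl carbon gave (a 32-fold lower number from compound 3 to compound 4 (1.51 log units; beyond the scatter)), so the high number of compound 3 went with that group and not with the ester link shared by all four compounds. Prop-1-en-1-yl could not be told apart from methyl (a 1.1-fold higher number from compound 1 to compound 4 (0.05 log units; within the scatter)), whereas the change from heptyl did register (a 2.6-fold lower number from compound 2 to compound 4 (0.41 log units; beyond the scatter)). No measurement offered here explains these differences.

Still open, as far as these compounds go, is which part of the large group carries the effect. An amine or a carboxylic acid at this carbonyl carbon might or might not reach the number of compound 3.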